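The source may report more compounds than this note shows. Statements on the series, on what has been measured and on what is new or still open speak of the compounds shown alone.

Measured in a functional assay on HL-60 cells (Homo sapiens) for antiproliferative activity, read by MTT assay, with a stated time of 48 h; on this read-out lower numbers stand for stronger inhibition and higher numbers for weaker inhibition:
compound 1, `CN(C)CCCn1c(N)c(-c2nc3ccccc3n2C)c2nc(C#N)c(C#N)nc21`: 2120 nM
compound 2, `CCN(CC)CCCn1c(N)c(-c2nc3ccccc3n2C)c2nc(C#N)c(C#N)nc21`: 2810 nM
compound 3, `CN(C)CCCCn1c(-c2c(N)n(C)c3nc(C#N)c(C#N)nc23)nc2ccccc21`: 2270 nM

Compound 4, `CCN(CC)CCCCn1c(-c2c(N)n(C)c3nc(C#N)c(C#N)nc23)nc2ccccc21`, has not yet been measured in this assay.

The three measured numbers sit close together. Compound 1 and compound 3 carry different cores; the difference between the two cores is not broken down here. Within the core of compound 1, one step is measured: a 1.3-fold higher number from compound 1 to compound 2 (0.12 log units; within the scatter), the change being (diethylamino in place of dimethylamino on a saturated chain carbon, three bonds along the chain from an aromatic nitrogen).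

The change from compound 3 to compound 4 is of the same kind: diethylamino in place of dimethylamino on a saturated chain carbon, four bonds along the chain from an aromatic nitrogen. It is not the same change, since the places differ in their printed words: in compound 1 the amine sits on a saturated chain carbon, three bonds along the chain from an aromatic nitrogen, whereas in compound 3 it sits on a saturated chain carbon, four bonds along the chain from an aromatic nitrogen.

For compound 4 the step expected in this assay is a 1.3-fold higher number from compound 3 to compound 4 (0.11 log units; within the scatter), set beside a 1.3-fold higher number from compound 1 to compound 2 (0.12 log units; within the scatter). Within the data shown here, this rests on a single precedent, the step from compound 1 to compound 2, which lay within the scatter, and on compound 3 giving 2270 nM, a number close to that of compound 1; a longer chain is the only difference in place and there is no measured step that reads on it.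

Compound 4 is therefore estimated at 2900 nM in this assay, with the expected range running from 1500 nM to 5500 nM.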

Compound 4, half-maximal inhibitory concentration: 2860 nM
Compound 4: middle estimate off by 1.0-fold (0.01 log units), on the high side; measured number inside the range.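

In this assay, diethylamino in place of dimethylamino on a saturated chain carbon, four bonds along the chain from an aromatic nitrogen, gives a 1.3-fold higher number from compound 3 to compound 4 (0.10 log units; within the scatter), and the earlier step on the other core reads the same: the same change on two cores in this assay, a 1.3-fold higher number (0.12 log units; within the scatter) from compound 1 to compound 2 and a 1.3-fold higher number (0.10 log units; within the scatter) from compound 3 to compound 4, 1.1-fold (0.02 log units) apart, within the scatter of two such steps Across these two cores, then, the change carries over without any visible difference, and on neither core can the diethylamino compound be told apart from its dimethylamino partner on this read-out. Among these compounds, this does not show that the effect of the change is conserved in any stronger sense: both steps lie within the scatter, so the agreement is between two steps too small to read, it rests on only two pairs, and the two pairs differ in chain as well as in core, with the amine three bonds along the chain from an aromatic nitrogen in one and four bonds along in the other.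

The compounds shown hold no pair that separates chain length from core, so the contribution of each remains open. Also open, from the compounds shown here alone, is whether a ring amine such as piperidine or morpholine, or a longer chain, would move the number beyond the scatter on either core.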